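A few compounds are considered here, and "the series" means these few. Any claim that something is new, unique, unknown or untested is made for them only; others in the source may bear on it.

Compound 1 `CS(=O)(=O)Nc1cccc2c1CCC2c1ncc[nH]1`: in a functional assay on CHO cells for agonist activity at Alpha-1D adrenergic receptor (Homo sapiens), read by FLIPR and calcium flux (a higher number here means that more compound is needed for the effect, a lower number that less compound is needed), compound 1 gives only the limit > 10000 nM. Compound 2 `c1cc(-c2cn[nH]c2)c2c(c1)C(c1ncc[nH]1)CC2`: compound 2 gives 319 nM. Compound 3 `Cc1c(OCC2=NCCN2)ccc(Cl)c1NS(C)(=O)=O`: compound 3 gives only the limit > 10000 nM.

For the measured compounds named here, compound 2 thus stands alone with the only numerical value, while the other two sit at the limit of > 10000 nM in this assay, at which 2 of the 3 values shown sit. Going by the values given here, the single measured step, an at least 31-fold lower number from compound 1 to compound 2 (1.49 log units; beyond the scatter), shows how strongly the group on that aromatic carbon can move the number. Compound 4 `c1ccc(-c2cccc3c2CCC3c2ncc[nH]2)nc1` differs from compound 2 as follows: pyridin-2-yl in place of 1H-pyrazol-4-yl on an aromatic carbon. Among the compounds with values here, no measured step covers this exchange, so the expectation is uncertain. A weakening step a 3.8-fold higher number from compound 2 to compound 4 (0.58 log units; beyond the scatter) is expected. Compound 4 is therefore estimated at 1200 nM, within 200 nM to 8000 nM.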

Compound 4, half-maximal effective concentration: > 10000 nM
Compound 4 was reported as a limit (the forecaster's own chance of this, stated with the estimate: 25%); at least 8.3-fold (0.92 log units) between middle value and limit.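

Exchanging one aromatic ring for another on this carbon is far from a neutral swap: in this assay, pyridin-2-yl in place of 1H-pyrazol-4-yl gives an at least 31-fold higher number from compound 2 to compound 4 (1.49 log units; beyond the scatter). The earlier step therefore did not mean that any aromatic ring would serve here, and of the three groups shown at this position, only 1H-pyrazol-4-yl gives a number rather than a limit. The step between compound 1 and compound 4 cannot be read, as both values are limits.

This exchange changes ring size and removes the hydrogen-bond donor together, so the compounds shown cannot separate the two. On these data alone, whether a small amine or a phenyl ring on this carbon would give a measurable number also remains open.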